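Chain extension on two purine-like cores in HCT-116 cells

This account rests on a few compounds, and the source may have more. Where it says the series, first, only, none or still open, it means among the compounds named here.

Measured compounds:
compound 1, `CCCCCCCC(CCO)n1cnc2c(N)nc(Cl)nc21`: > 50000 nM
compound 2, `CCCCCCCCC(CCO)n1cnc2c(Cl)nc(F)nc21`: 24200 nM
compound 3, `CCCCCCCCC(CCO)n1cnc2c(N)nc(Cl)nc21`: 21000 nM

Three compounds have been run in a functional assay on HCT-116 cells (Homo sapiens) for antiproliferative activity, read by MTT assay, with a stated time of 48 h; on this read-out lower numbers stand for stronger inhibition and higher numbers for weaker inhibition. For compound 1 the result is a limit of this assay and not a number, > 50000 nM. Compound 3 gives 21000 nM, and compound 2 gives 24200 nM; the values of compounds 2 and 3 lie within the usual scatter of each other. Compound 1 and compound 3 share one core and differ only by methyl in place of hydrogen on a saturated chain carbon, eight bonds along the chain from an aromatic nitrogen, which gave an at least 2.3-fold lower number from compound 1 to compound 3 (0.37 log units; beyond the scatter); the step can only be given as a lower bound because compound 1 sits at the limit of > 50000 nM in this assay, at which 1 of the 3 values shown sits. The difference between the core of compound 2 and the core of compound 1 is not broken down here.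

Compound 4, `CCCCCCCCCC(CCO)n1cnc2c(Cl)nc(F)nc21`, has not yet been measured in this assay. It differs from compound 2 by methyl in place of hydrogen on a saturated chain carbon, nine bonds along the chain from an aromatic nitrogen, the same kind of change as from compound 1 to compound 3, though one bond further out along the chain. On the strength of compound 2 at 24200 nM and the earlier step of an at least 2.3-fold lower number from compound 1 to compound 3 (0.37 log units; beyond the scatter), a step of a 2.0-fold lower number from compound 2 to compound 4 (0.30 log units; within the scatter) is expected. Compound 4 is therefore estimated at 12000 nM, with a likely range from 5000 nM to 30000 nM.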

Compound 4, half-maximal inhibitory concentration: 32100 nM
Estimate against measurement, compound 4: 2.7-fold (0.43 log units) below; measured number above the stated range.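

In this assay, methyl in place of hydrogen on a saturated chain carbon, nine bonds along the chain from an aromatic nitrogen, gave a 1.3-fold higher number from compound 2 to compound 4 (0.12 log units; within the scatter), so on this core the added methyl produced no difference that stands out from the usual scatter. Set beside the earlier step, the same kind of change did not carry over unchanged from one core to the other: the same change on two cores in this assay, an at least 2.3-fold lower number (0.37 log units; beyond the scatter) from compound 1 to compound 3 and a 1.3-fold higher number (0.12 log units; within the scatter) from compound 2 to compound 4, at least 3.1-fold (0.49 log units) apart, beyond the scatter of two such steps

This does not show that the core alone decides the outcome, as the two pairs also differ in chain length, with the change one bond further out in the second pair, and the earlier step is only a bound: the limit of > 50000 nM in this assay, at which 1 of the 4 values shown sits.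

The compounds shown leave open how the core of compound 1 would read with the chain of compound 4, which would put one chain on both cores. Also open, going by these compounds, is whether a longer chain, or a carboxylic acid in place of the hydroxyl group, would give a step beyond the scatter on either core.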